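The source may hold more compounds than are shown below. What is called first, only, known or untested is meant among the compounds shown, and "the series" means these compounds.

Values measured so far in a functional assay on HCT-116 cells (Homo sapiens) for antiproliferative activity, read by MTT assay, with a stated time of 24 h (a higher number here means a weaker inhibitor, a lower number a stronger inhibitor), are these:

Compound 1 `COc1cc(OC)c(-c2coc3cc(OCc4ccccc4)ccc3c2=O)cc1OC` gives 2280 nM
Compound 2 `COc1cc(OC)c(-c2coc3cc(OCc4ccccc4C(F)(F)F)ccc3c2=O)cc1OC` gives 4760 nM
Compound 3 `COc1cc(OC)c(-c2coc3cc(OCc4ccc(C#N)cc4)ccc3c2=O)cc1OC` gives 4220 nM

Compound 3 stands within the scatter of both other compounds, with a 1.9-fold higher number from compound 1 to compound 3 (0.27 log units; within the scatter) on one side and a 1.1-fold lower number from compound 2 to compound 3 (0.05 log units; within the scatter) on the other. The change that leads to compound 4 `COc1cc(OC)c(-c2coc3cc(OCc4cccc(Br)c4)ccc3c2=O)cc1OC` is 3-bromophenyl in place of 4-cyanophenyl on a saturated chain carbon bound to an oxygen on an aromatic ring on a saturated chain carbon bound to an oxygen on an aromatic ring. Among the compounds with values here, three measured steps bear on it. Trifluoromethyl in place of hydrogen gave a 2.1-fold higher number from compound 1 to compound 2 (0.32 log units; beyond the scatter) and cyano in place of hydrogen gave a 1.9-fold higher number from compound 1 to compound 3 (0.27 log units; within the scatter) while the exchange of those two substituted phenyl groups gave a 1.1-fold lower number from compound 2 to compound 3 (0.05 log units; within the scatter) as well. Within the data shown here, no measured compound carries bromine, so the expectation rests on these small steps alone. In this assay no step beyond the scatter is therefore expected, and the estimate is a 1.2-fold lower number from compound 3 to compound 4 (0.08 log units; within the scatter) in either direction. Compound 4 is estimated at 3500 nM with an expected range from 1700 nM to 7000 nM when measured.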

Compound 4, half-maximal inhibitory concentration: 1200 nM
Beside the measured number, compound 4's estimate is 2.9-fold (0.46 log units) above it; the measured number lies below the stated range.
By their numbers in this assay, from the lowest: compounds 4, 1, 3 and 2 (each within the scatter of the next, the first and the last beyond it).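

In this assay, 3-bromophenyl in place of 4-cyanophenyl gave a 3.5-fold lower number from compound 3 to compound 4 (0.55 log units; beyond the scatter) and 3-bromophenyl in place of 2-(trifluoromethyl)phenyl gave a 4.0-fold lower number from compound 2 to compound 4 (0.60 log units; beyond the scatter), so exchanging one substituted phenyl group for another at this place can move the number beyond the scatter, which the exchange between the two earlier groups did not do. Bromo in place of hydrogen, by contrast, gave a 1.9-fold lower number from compound 1 to compound 4 (0.28 log units; within the scatter), so the bromine sets compound 4 apart from the two other substituted compounds but not from the unsubstituted phenyl group of compound 1. Nothing available explains the difference among these groups.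

The compounds shown cannot separate the effect of bromine itself from that of its place on the ring. As far as these compounds go, how a chloro group, a methoxy group, an amine or a longer chain at this place would read in this assay remains open.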